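Ethoxy Out, Dimethylamino In at the Carbonyl Carbon

A few compounds are considered here, and "the series" means these few. Any claim that something is new, unique, unknown or untested is made for them only; others in the source may bear on it.

The measured compounds and their numbers:

Compound 1, `CNC(=O)/C=C/c1ccncc1-c1ccc2cccnc2c1`: 82%
Compound 2, `CCOC(=O)/C=C/c1ccncc1-c1ccc2[nH]ccc2c1`: 100%
Compound 3, `CCOC(=O)/C=C/c1ccncc1-c1ccc2ccccc2c1`: 102%

All three were tested in an assay on a protein complex for inhibition of CDK8/Cyclin C (Homo sapiens), with a stated time of 1 h, tested at 10 uM; on this read-out lower numbers stand for less inhibition and higher numbers for more inhibition at the one concentration tested (going by the name of the read-out). For the measured compounds named here, compound 3 stands at the top of the three numbers, though its gap to compound 2 lies within the scatter, so the two cannot be ranked against each other; only compound 1, the one compound in the set whose chain ends in an amide rather than an ester, sits clearly lower, beyond the scatter. Compound 1 also differs from compound 3 in its core, so its lower value cannot be tied to one change alone.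

Compound 4, `CN(C)C(=O)/C=C/c1ccncc1-c1ccc2ccccc2c1`, keeps the core of compound 3 and changes only the chain end: dimethylamino in place of ethoxy on a carbonyl carbon.

Going by the values given here, no measured pair isolates this change. The only hint is that the one amide in the set, compound 1, gives 82%, below both esters. Compound 4 is therefore expected to lose some inhibition, with a step of a number 17 percentage points lower from compound 3 to compound 4 (beyond the scatter) that is estimated to fall at or somewhat beyond the scatter. Compound 4 is expected to give about 85%, in a range from 65% to 100%.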

Compound 4, a percentage reported as inhibition, at one concentration (the size of the read-out at that concentration, not a potency): 100%
For compound 4 the middle estimate is 15 percentage points below the measured one; low and high end bracket the measured number.
By their numbers in this assay, from the lowest: compound 1; then compounds 2, 4 and 3 (each within the scatter of the next).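

In this assay, dimethylamino in place of ethoxy on the carbonyl carbon gives a number 2 percentage points lower from compound 3 to compound 4 (within the scatter), so on this shared core the ester and amide chain ends cannot be told apart. For the compounds shown here, this is the first direct look at the change, and it shows that an amide at this chain end can read as high as the ester, so the amide alone does not bring a clear loss on this core. No measurement here explains why the swap leaves the reading within the scatter.

The reading is the size of inhibition at one concentration, not a potency, so a real difference in potency between the ester and the amide may still lie hidden in this assay. On these data alone, compound 1 differs from compound 4 in both its core and its amide, so its place cannot be assigned to either part, and it remains open how the methylamino end would read on the core of compound 3 or how a carboxylic acid or a morpholine amide would read at this carbonyl carbon.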